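The source may hold more compounds than are shown below. What is called first, only, known or untested is meant among the compounds shown, and "the series" means these compounds.

Of the compounds shown here, three that share one core have been measured in an assay on HEK293 cells for inhibition of kynurenine 3-monooxygenase (Homo sapiens), read by LC-MS, with a stated time of 20 h; on this read-out lower numbers stand for stronger inhibition and higher numbers for weaker inhibition. Compound 1 `Cc1ccc([C@@H](C)Oc2cc3onc(CCC(=O)O)c3cc2Cl)nn1` gives 3.16 nM, compound 2 `C[C@@H](Oc1cc2onc(CCC(=O)O)c2cc1Cl)c1ccc(F)cn1` gives 31.6 nM, and compound 3 `C[C@@H](Oc1cc2onc(CCC(=O)O)c2cc1Cl)c1ccc(Cl)cn1` gives 3.98 nM. Compound 3 therefore holds the second highest of the three numbers: its value and that of compound 1 cannot be told apart, since a 1.3-fold higher number from compound 1 to compound 3 (0.10 log units; within the scatter), while compound 2 is set apart from it by a 7.9-fold lower number from compound 2 to compound 3 (0.90 log units; beyond the scatter).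

Compound 4 `C[C@@H](Oc1cc2onc(CCC(=O)O)c2cc1Cl)c1ccccn1` is not yet measured. It differs from compound 3 in one place: hydrogen in place of chloro on an aromatic carbon, on an aromatic carbon of a six-membered aromatic ring with one nitrogen, two atoms from the ring nitrogen. Two measured steps speak to this change. Swapping the whole aryl group gave a 10-fold higher number from compound 1 to compound 2 (1.00 log units; beyond the scatter), and the halogen swap on the same aromatic carbon gave a 7.9-fold lower number from compound 2 to compound 3 (0.90 log units; beyond the scatter). Taking the chlorine away altogether, leaving only hydrogen, is expected to move the number in the same direction as the fluorine case, so a step beyond the scatter is expected, namely a 5.0-fold higher number from compound 3 to compound 4 (0.70 log units; beyond the scatter). On that basis compound 4 is estimated to give 20 nM in this assay, most likely between 6 nM and 80 nM.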

Compound 4, half-maximal inhibitory concentration in the kynurenine 3-monooxygenase assay: 3.16 nM
Compound 4: middle estimate off by 6.3-fold (0.80 log units), on the high side, outside the stated range (below it).
By their numbers in the kynurenine 3-monooxygenase assay, from the lowest: compounds 1, 4 and 3 (each within the scatter of the next); then compound 2.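

In the kynurenine 3-monooxygenase assay, the chloro group at this place, para to a large group, turns out not to be needed: compound 3 gives 3.98 nM and compound 4 gives 3.16 nM, which leaves the result within the scatter (a 1.3-fold lower number from compound 3 to compound 4 (0.10 log units; within the scatter)). The earlier compounds shown here could suggest that this place favours chloro over fluoro, but with hydrogen added the picture changes: hydrogen and chloro cannot be told apart, and only the fluoro of compound 2 stands off, with a step beyond the scatter (a 10-fold lower number from compound 2 to compound 4 (1.00 log units; beyond the scatter)), so the numbers do not run in order from hydrogen through fluoro to chloro across these three compounds. The plain pyridin-2-yl group also cannot be told apart from the 6-methylpyridazin-3-yl group of compound 1 (no change at the digits printed from compound 1 to compound 4 (within the scatter)).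

Nothing measured here accounts for why the fluoro compound alone stands apart from the hydrogen and chloro compounds. In a physicochemical assay for solubility, with a stated time of 24 h (on this read-out lower numbers stand for lower solubility and higher numbers for higher solubility), compound 3 gives > 620 ug/mL, which is a limit of the assay and not a number. In the physicochemical assay compound 4 gives > 7440 ug/mL, which is likewise a limit of the assay. As far as these compounds go, both values in the physicochemical assay are limits, so the step between compound 3 and compound 4 there cannot be read, and whether a larger group at this place, such as methoxy, would also stay within the scatter of hydrogen and chloro remains open.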